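Thiazole for bromothiophene on the bicyclic amine

The compounds below may be only part of what the source reports. "The series", "measured", "known", "first", "only" and "open" are said of these compounds alone.

Going by the values given here, compound 3 `C[C@H]1[C@H](NCc2ccc(Br)s2)C[C@H]2C[C@@H]1C2(C)C` gives 43000 nM in an ADME assay on MDCK cells (Canis lupus familiaris) for cytotoxicity, read by microscopy, with a stated time of 48 h (on this read-out higher numbers stand for lower toxicity in this test and lower numbers for higher toxicity in this test), and has the highest of the three numbers measured so far. Its nearest neighbour is compound 1 `CSc1ccc(CN[C@@H]2C[C@H]3C[C@@H]([C@H]2C)C3(C)C)s1` with 25000 nM, the step of a 1.7-fold higher number from compound 1 to compound 3 (0.24 log units; within the scatter). Furthest is compound 2 `CCc1ccc(CN[C@@H]2C[C@H]3C[C@@H]([C@H]2C)C3(C)C)s1` with 1560 nM, the step of a 28-fold higher number from compound 2 to compound 3 (1.44 log units; beyond the scatter); between those two the step of a 16-fold lower number from compound 1 to compound 2 (1.20 log units; beyond the scatter) completes the picture.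

Compound 4 `Cc1csc(CN[C@@H]2C[C@H]3C[C@@H]([C@H]2C)C3(C)C)n1` carries the change (4-methyl-1,3-thiazol-2-yl in place of 5-bromothiophen-2-yl on a saturated chain carbon bound to an amine nitrogen). Among the compounds with values here, no measured step bears on it directly: every step so far exchanges the group on an aromatic carbon while the ring itself stays the same, whereas here the ring is exchanged. Those steps show that one exchange on the ring leaves the number inside the scatter and another moves it far, so a large move in either direction cannot be ruled out. In the absence of a closer precedent a moderate downward step, a 2.9-fold lower number from compound 3 to compound 4 (0.46 log units; beyond the scatter), is expected, with a wide range. Compound 4 is therefore estimated at 15000 nM, between 3000 nM and 60000 nM.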

Compound 4, minimum cytotoxic concentration: > 100000 nM
Compound 4: no number, only a limit; the forecaster's own chance of this, stated with the estimate: 10%; middle value at least 6.6-fold (0.82 log units) away from the limit.
By their numbers in this assay, from the lowest: compound 2; then compounds 1 and 3 (each within the scatter of the next). At a limit, above all of these: compound 4.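

Going by these compounds alone, exchanging the ring itself, which no earlier step did, gives an at least 2.3-fold higher number from compound 3 to compound 4 (0.36 log units; beyond the scatter) in this assay, so 4-methyl-1,3-thiazol-2-yl in place of 5-bromothiophen-2-yl on a saturated chain carbon bound to an amine nitrogen points towards lower toxicity in this test. Compound 4 has no number, only a limit of the assay: the limit of > 100000 nM in this assay, at which 1 of the 4 values shown sits. From the compounds shown here alone, the earlier large moves came from exchanging a group on an aromatic carbon, such as a 16-fold lower number from compound 1 to compound 2 (1.20 log units; beyond the scatter); this result shows that the ring exchange also moves the number beyond the scatter, though the full size of the step remains unknown.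

The compounds shown do not separate the part played by the ring nitrogen from that of the methyl group, as they include no unsubstituted 1,3-thiazol-2-yl. Going by these compounds, how an ethyl group, a bromo group or a carboxylic acid on the thiazole would read also remains open.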